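Swapping fluoro for methylsulfanyl: how large a step?

A few compounds are considered here, and "the series" means these few. Any claim that something is new, unique, unknown or untested is made for them only; others in the source may bear on it.

In a functional assay on WM 266-4 cells (Homo sapiens) for antiproliferative activity, read by MTT assay, with a stated time of 24 h (on this read-out higher numbers stand for weaker inhibition of growth and lower numbers for stronger inhibition of growth), compound 1 `c1ccc(N2N=C(c3ccc4c(c3)OCCO4)CC2c2ccco2)cc1` gives > 100000 nM as its result, which is a limit of the assay and not a number. Compound 2 `Fc1ccccc1C1CC(c2ccc3c(c2)OCCO3)=NN1c1ccccc1` gives 9120 nM and compound 3 `Fc1ccc(C2CC(c3ccc4c(c3)OCCO4)=NN2c2ccccc2)cc1` gives 6050 nM as measured numbers. Compound 3 therefore stands level with compound 2, since a 1.5-fold lower number from compound 2 to compound 3 (0.18 log units; within the scatter) stays within the scatter.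

Compound 4 `CSc1ccc(C2CC(c3ccc4c(c3)OCCO4)=NN2c2ccccc2)cc1` is still unmeasured. It turns 4-fluorophenyl into 4-(methylsulfanyl)phenyl, with methylsulfanyl in place of fluoro on an aromatic carbon, para to a large group: methylsulfanyl in place of fluoro on an aromatic carbon describes the swap.

The large steps, an at least 10-fold lower number from compound 1 to compound 2 (1.04 log units; beyond the scatter) and an at least 16-fold lower number from compound 1 to compound 3 (1.21 log units; beyond the scatter), both replaced furan-2-yl, and both start from a limit. Among the compounds with values here, this swap keeps the phenyl ring, so the closer guide is the small change seen in a 1.5-fold lower number from compound 2 to compound 3 (0.18 log units; within the scatter), although no measured step replaces the fluoro itself.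

No step beyond the scatter is therefore expected in this assay, and the estimated change is a 1.2-fold lower number from compound 3 to compound 4 (0.08 log units; within the scatter) overall. For compound 4 the expected value is 5000 nM, with an estimated range from 1000 nM to 20000 nM overall.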

Compound 4, concentration for 50% growth inhibition: 6870 nM
Estimate against measurement, compound 4: 1.4-fold (0.14 log units) below; the range from low to high includes it.
By their numbers in this assay, from the lowest: compounds 3, 4 and 2 (each within the scatter of the next). At a limit, above all of these: compound 1.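

In this assay the first replacement of the fluoro itself, para to a large group, gives a 1.1-fold higher number from compound 3 to compound 4 (0.06 log units; within the scatter) and so moves the result by nothing beyond the scatter, even though a carbon and a sulfur now stand where one fluorine stood. With a 1.3-fold lower number from compound 2 to compound 4 (0.12 log units; within the scatter) as well, 4-(methylsulfanyl)phenyl sits level with 2-fluorophenyl, while an at least 14-fold lower number from compound 1 to compound 4 (1.16 log units; beyond the scatter) adds a third large step away from furan-2-yl. That large step starts from compound 1, whose result is a limit and not a number: the limit of > 100000 nM in this assay, at which 1 of the 4 values shown sits.

Fluoro and methylsulfanyl alone cannot show how much this place would accept, so an amine, a carboxylic acid or a longer chain such as butylsulfanyl could still give a different result. As far as these compounds go, whether methylsulfanyl would behave alike at the place held by the fluoro of compound 2 also stays open.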